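The source may hold more compounds than are shown below. What is called first, only, known or untested is meant among the compounds shown, and "the series" means these compounds.

Measured so far:
- compound 1, `COc1cc(N)c(Cl)cc1C(=O)NC1CCN(CCCCCO)CC1` — 63.1 nM
- compound 2, `COc1cc(N)c(Cl)cc1C(=O)NC1CCN(CCCCCCCCO)CC1` — 79.4 nM
- compound 3, `COc1cc(N)c(Cl)cc1C(=O)NC1CCN(CCCCCCCCS(=O)(=O)O)CC1` — 15800 nM

All three share the same core and differ only at the end of the chain on the ring amine nitrogen. In an assay on HEK293 cells for displacement of a labelled ligand from 5-hydroxytryptamine receptor 4 (Homo sapiens), read by scintillation counting (a lower number here means a stronger inhibitor, a higher number a weaker inhibitor), compound 3 gives the highest of the three numbers: the nearest is compound 2, reached by a 200-fold higher number from compound 2 to compound 3 (2.30 log units; beyond the scatter), and the furthest is compound 1, reached by a 250-fold higher number from compound 1 to compound 3 (2.40 log units; beyond the scatter). Between the two hydroxy compounds the difference is small, a 1.3-fold higher number from compound 1 to compound 2 (0.10 log units; within the scatter).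

Compound 4, `COc1cc(N)c(Cl)cc1C(=O)NC1CCN(CCCCCN2CCN(S(C)(=O)=O)CC2)CC1`, is not yet measured. It is made from compound 3 by 4-(methylsulfonyl)piperazin-1-yl in place of 3-sulfopropyl on a saturated chain carbon, five bonds along the chain from an amine nitrogen in a ring. The group that leaves is exactly the one whose entry produced the two large rises already seen, so those two steps bear directly on this one, both in the direction of a much higher number; compound 4 carries no hydroxy either, so the hydroxy compounds 1 and 2 serve only as a rough reference for a chain end without the sulfo group. Compound 4 is therefore expected to show a large drop in this assay, estimated as a 320-fold lower number from compound 3 to compound 4 (2.50 log units; beyond the scatter). The estimate for compound 4 is 50 nM, with a range from 10 nM to 300 nM.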

Compound 4, inhibition constant: 39.8 nM
Estimate against measurement, compound 4: 1.3-fold (0.10 log units) above; measured number inside the range.
By their numbers in this assay, from the lowest: compounds 4, 1 and 2 (each within the scatter of the next); then compound 3.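

In this assay, replacing the 3-sulfopropyl part of the chain end with 4-(methylsulfonyl)piperazin-1-yl brings a large fall (a 400-fold lower number from compound 3 to compound 4 (2.60 log units; beyond the scatter)), so the high number of compound 3 does not follow from a chain end carrying sulfur with two double-bonded oxygens alone, since both of these groups have that. The hydroxy compounds showed only that this position tolerated a change of chain length, whereas the comparisons with them (a 1.6-fold lower number from compound 1 to compound 4 (0.20 log units; within the scatter) and a 2.0-fold lower number from compound 2 to compound 4 (0.30 log units; within the scatter)) stay within the scatter even though the entering group brings a six-membered non-aromatic ring and 10 heavy atoms. Among these compounds, then, only the sulfo end of compound 3 stands apart, and nothing measured here explains why. Going by these compounds, it remains open whether a carboxylic acid at the end of the chain would also give a large rise, or whether the sulfo group would do so on a shorter chain. Equally open, on these data alone, is whether a plain piperazine, without the methylsulfonyl group, or a longer chain carrying the 4-(methylsulfonyl)piperazin-1-yl group would stay level with compound 4.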